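From allyl to ethyl: compound 3 to compound 4

This account rests on a few compounds, and the source may have more. Where it says the series, first, only, none or still open, it means among the compounds named here.

- compound 1 `CCNC(=O)Nc1nc2cc(-c3cccnc3)c(=O)n(CC)c2s1` gives 0.11
- compound 2 `CCNC(=O)Nc1nc2cc(-c3cccnc3)c(=O)n(CC3CC3)c2s1` gives 0.05
- compound 3 `C=CCNC(=O)Nc1nc2cc(-c3cccnc3)c(=O)n(CCC(C)C)c2s1` gives 0.03

All three numbers come from an ADME assay on a cell-free system (plasma, Homo sapiens) (a higher number here means a larger unbound share of the compound, a lower number a smaller unbound share), and share one core. Compound 3 lies within the scatter of compound 2, and beyond the scatter with a lower number than compound 1. The next compound is compound 4 `CCNC(=O)Nc1nc2cc(-c3cccnc3)c(=O)n(CCC(C)C)c2s1` with one small difference from compound 3: methyl in place of vinyl on a saturated chain carbon bound to an amide-type nitrogen. In words, this is methyl in place of vinyl on a saturated chain carbon bound to an amide-type nitrogen, which can also be read as allyl to ethyl. Within the data shown here, no measured pair changes that place. Among the measured compounds shown here, the only measured step is a 2.2-fold lower number from compound 1 to compound 2 (0.34 log units; beyond the scatter) and it is modest. It sits elsewhere, as cyclopropyl in place of methyl on a saturated chain carbon bound to an aromatic nitrogen, so it offers only a loose guide. No change beyond the scatter is therefore expected in this assay here. The expected step is a 1.2-fold higher number from compound 3 to compound 4 (0.07 log units; within the scatter) and it should stay small. For compound 4 the estimated value is 0.035 with an expected range from 0.02 to 0.06 overall.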

Compound 4, unbound fraction: 0.06
The estimate for compound 4 lay 1.7-fold (0.23 log units) below the measured number, within the range that was stated.
By their numbers in this assay, from the lowest: compounds 3, 2, 4 and 1 (each within the scatter of the next, the first and the last beyond it).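

In this assay, among these compounds, the first measured change at this place, methyl in place of vinyl on a saturated chain carbon bound to an amide-type nitrogen, gives a 2.0-fold higher number from compound 3 to compound 4 (0.30 log units; within the scatter), so allyl and ethyl cannot be told apart here. With ethyl kept at that place, compound 4 also stays within the scatter of both compounds that differ from it at the aromatic nitrogen, with a 1.2-fold higher number from compound 2 to compound 4 (0.08 log units; within the scatter) and a 1.8-fold lower number from compound 1 to compound 4 (0.26 log units; within the scatter), although a 2.2-fold lower number from compound 1 to compound 2 (0.34 log units; beyond the scatter) does go beyond it. No measurement on hand explains any of these numbers. Going by these compounds, whether a longer chain, a hydroxyl or an amine at the amide-type nitrogen's chain carbon would move the unbound share beyond the scatter remains open. So does whether a carboxylic acid there would do so.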